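This account rests on a few compounds, and the source may have more. Where it says the series, first, only, none or still open, it means among the compounds named here.

Measured in a functional assay on PC-3 cells (Homo sapiens) for cytotoxicity, read by sulforhodamine B assay, with a stated time of 48 h; on this read-out lower numbers stand for higher toxicity in this test and higher numbers for lower toxicity in this test:

compound 1 `ClCc1ccc(Cn2cnc3c(Cl)ncnc32)cc1` gives only a limit of the assay, > 100000 nM.
compound 2 `Nc1nc(Cl)c2ncn(Cc3ccc(CCl)cc3)c2n1` gives 70800 nM.
compound 3 `ClCc1ccccc1Cn1cnc2c(Cl)ncnc21` gives 53700 nM.

Compound 3 and compound 1 have the same atoms joined differently; the difference between the two cores is not broken down here. In this assay compound 3 and compound 2 sit within the scatter of each other.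

The change amino in place of hydrogen on an aromatic carbon gave an at least 1.4-fold lower number from compound 1 to compound 2 (0.14 log units; that floor lies within the scatter), a floor set by the limit of > 100000 nM in this assay, at which 1 of the 3 values shown sits.

Compound 4 `Nc1nc(Cl)c2ncn(Cc3ccccc3CCl)c2n1` carries the same change on the core of compound 3: amino in place of hydrogen on an aromatic carbon. The two places read the same word for word.

The step from compound 3 to compound 4 in this assay is expected to be a 1.3-fold lower number from compound 3 to compound 4 (0.13 log units; within the scatter), a small change resting on an at least 1.4-fold lower number from compound 1 to compound 2 (0.14 log units; that floor lies within the scatter), which itself is only a floor within the scatter. Compound 4 is estimated at 40000 nM, between 15000 nM and 100000 nM.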

Compound 4, concentration lethal to 50% of the cells: > 100000 nM
Compound 4: a limit, no number; the forecaster's own chance of this, stated with the estimate: 15%; at least 2.5-fold (0.39 log units) between middle value and limit.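

In this assay compound 4 gives > 100000 nM, which is a limit of the assay and not a number. Amino in place of hydrogen on an aromatic carbon gives an at least 1.8-fold higher number from compound 3 to compound 4 (0.27 log units; that floor lies within the scatter), and beside the earlier step this does not settle whether the change carries from one core to the other: the same change on two cores in this assay, an at least 1.4-fold lower number (0.14 log units; that floor lies within the scatter) from compound 1 to compound 2 and an at least 1.8-fold higher number (0.27 log units; that floor lies within the scatter) from compound 3 to compound 4; the limit leaves it open whether they differ. Both steps are floors within the scatter, so neither a shared effect nor an opposite effect of the change on the two cores is shown, and much of the series rests on one limit: the limit of > 100000 nM in this assay, at which 2 of the 4 values shown sit.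

Still open, on these data alone, is how either core would read with a methylamino or a hydroxyl group in place of the amino group on the same aromatic carbon. Also open, as far as these compounds go, is whether any such group would give a number rather than a limit in this assay.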